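Methyl on a phenol oxygen: effect on liver-cell tolerance

The source may hold more compounds than are shown below. What is called first, only, known or untested is meant among the compounds shown, and "the series" means these compounds.

The measured compounds:
- compound 1, `COc1cc(O)c(C(=O)O)c(C=Cc2ccc3ccccc3c2)c1`: in an ADME assay on HepG2 cells (Homo sapiens) for cytotoxicity, read by resazurin assay, with a stated time of 24 h (a higher number here means that more compound is tolerated, a lower number that less compound is tolerated), compound 1 gives 79000 nM
- compound 2, `COc1cc(C=Cc2ccc3ccccc3c2)c(C(=O)O)c(OC)c1`: compound 2 gives only a limit of this assay, > 100000 nM
- compound 3, `CCN(CC)C(=O)c1c(O)cccc1CCc1ccc2ccccc2c1`: compound 3 likewise gives only a limit, > 100000 nM

From compound 1 to compound 2 the change is methyl in place of hydrogen on an oxygen on an aromatic ring. This gave an at least 1.2-fold higher number from compound 1 to compound 2 (0.10 log units; that floor lies within the scatter), and that step is set by the fact that compound 2 sits at the limit of > 100000 nM in this assay, at which 2 of the 3 values shown sit. Compound 4, `CCN(CC)C(=O)c1c(CCc2ccc3ccccc3c2)cccc1OC`, is not yet measured; from compound 3 it differs by the same change, (methyl in place of hydrogen on an oxygen on an aromatic ring). The difference between the cores of compound 1 and compound 3 is not broken down here. Because compound 3 already stands at the limit (the limit of > 100000 nM in this assay, at which 2 of the 3 values shown sit), the step is expected to be a step that the limit leaves unreadable from compound 3 to compound 4. Compound 4 is expected to give about 120000 nM, most likely again as a limit, within 60000 nM to 250000 nM.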

Compound 4, half-maximal cytotoxic concentration: 35800 nM
The estimate for compound 4 lay 3.4-fold (0.53 log units) above the measured number; measured number below the stated range.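

In this assay, the change from hydroxy to methoxy gave an at least 2.7-fold lower number from compound 3 to compound 4 (0.44 log units; beyond the scatter), so less compound is tolerated after this change on the core of compound 3. The same change therefore did not carry over with the same result from one core to the other: the same change on two cores in this assay, an at least 1.2-fold higher number (0.10 log units; that floor lies within the scatter) from compound 1 to compound 2 and an at least 2.7-fold lower number (0.44 log units; beyond the scatter) from compound 3 to compound 4, at least 3.5-fold (0.54 log units) apart, beyond the scatter of two such steps. From the compounds shown here alone, compound 3 gives > 100000 nM, which is a limit and not a number, so the true size of this step stays unknown, and nothing here shows which difference between the two cores sets the two outcomes apart.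

Going by these compounds, whether an ethyl group or a longer chain on that oxygen would follow methyl on either core stays open. So does how an amine in place of the hydroxy group would fare.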